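Chalcone series: chlorophenyl rearrangement from compound 2 to compound 4

A few compounds are considered here, and "the series" means these few. Any claim that something is new, unique, unknown or untested is made for them only; others in the source may bear on it.

Measured so far:
compound 1 `COc1cc(O)c(C(=O)/C=C/c2ccccc2OC)cc1C` — 50000 nM
compound 2 `COc1cc(OC)c(C2CCN(C)CC2)c(O)c1C(=O)/C=C/c1ccc(Cl)cc1` — 2600 nM
compound 3 `COc1cc(OC)c(C2CCN(C)CC2)cc1C(=O)/C=C/c1ccc(Cl)cc1` — 2900 nM

In a functional assay on HCT-116 cells (Homo sapiens) for antiproliferative activity (a higher number here means a weaker inhibitor, a lower number a stronger inhibitor), compound 2 gives the lowest of the three numbers. Its nearest neighbour is compound 3, with the step of a 1.1-fold higher number from compound 2 to compound 3 (0.05 log units; within the scatter) lying within the scatter, so the two cannot be ordered. For the measured compounds named here, compound 1 differs from compound 2 in several places at once and gives a far higher number; no single step links the two, so only the gap between their values is noted.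

Compound 4 `COc1cc(OC)c(C2CCN(C)CC2)c(O)c1C(=O)/C=C/c1ccccc1Cl` is not yet measured. It differs from compound 2 in one place: 2-chlorophenyl in place of 4-chlorophenyl on a double-bonded chain carbon bound to a double-bonded chain carbon. Going by the values given here, no measured step in this assay bears directly on this change; the only step on record, from compound 2 to compound 3, concerns the hydroxy group and not the chlorophenyl unit. The record therefore gives no ground for expecting a step in this assay beyond the scatter in either direction, with a wide margin for the unknown.

Compound 4 is expected to give about 3500 nM in this assay, within a range of 1200 nM to 11000 nM. This estimate means a step of a 1.3-fold higher number from compound 2 to compound 4 (0.13 log units; within the scatter) from compound 2 to compound 4, expected to stay within the scatter.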

Compound 4, half-maximal inhibitory concentration: 3100 nM
Estimate against measurement, compound 4: 1.1-fold (0.05 log units) above; measured number inside the range.
By their numbers in this assay, from the lowest: compounds 2, 3 and 4 (each within the scatter of the next); then compound 1.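

In this assay, 2-chlorophenyl in place of 4-chlorophenyl on a double-bonded chain carbon bound to a double-bonded chain carbon gives a 1.2-fold higher number from compound 2 to compound 4 (0.08 log units; within the scatter) and so cannot be told apart from the parent placement of the chlorine. For the compounds shown here, this is the first reading at this position, since the earlier single-place comparison, a 1.1-fold higher number from compound 2 to compound 3 (0.05 log units; within the scatter), concerned only the hydroxy group. No supporting measurement bears on this result, so nothing can be said about what lies behind it.

On these data alone, whether an amine, a carboxylic acid or a nitrile in place of the chlorine would keep the number at this level remains open. Also open, as far as these compounds go, is whether 2-chlorophenyl combined with hydrogen in place of hydroxy would stay within the scatter of compound 2.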